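Amide tail variation on a butylbenzofuranoyl phenoxy series

The source may hold more compounds than are shown below. What is called first, only, known or untested is meant among the compounds shown, and "the series" means these compounds.

Measured compounds:
compound 1 `CCCCc1oc2ccccc2c1C(=O)c1ccc(OCC(=O)N2CCCC2)cc1` 32500 nM
compound 2 `CCCCc1oc2ccccc2c1C(=O)c1ccc(OCC(=O)N2CCCCC2)cc1` 37100 nM
compound 3 `CCCCc1oc2ccccc2c1C(=O)c1ccc(OCC(=O)Nc2cccc(OC)c2)cc1` 24200 nM

All three compounds share one core and differ only in the amide attached to the phenoxy-linked carbonyl. In a functional assay on U-937 cells (Homo sapiens) for antiproliferative activity, read by MTT assay, with a stated time of 24 h (a lower number here means a stronger inhibitor, a higher number a weaker inhibitor), compound 1 gives 32500 nM, compound 2 gives 37100 nM and compound 3 gives 24200 nM. Compound 2 carries the highest of the three numbers, but its nearest neighbour is compound 1 at a 1.1-fold higher number from compound 1 to compound 2 (0.06 log units; within the scatter) and the furthest is compound 3 at a 1.5-fold lower number from compound 2 to compound 3 (0.19 log units; within the scatter), so the three values sit within the scatter of one another and no order can be read among them. The step of a 1.3-fold lower number from compound 1 to compound 3 (0.13 log units; within the scatter) likewise lies within the scatter.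

The step to compound 4 `CCCCc1oc2ccccc2c1C(=O)c1ccc(OCCCC(=O)N2CCCC2)cc1`, not yet measured, is 2-((pyrrolidin-1-yl)carbonyl)ethyl in place of (piperidin-1-yl)carbonyl on a saturated chain carbon bound to an oxygen on an aromatic ring. Two things shift at once: the ring of the amide and the length of the chain between the aromatic oxygen and the carbonyl. Within the data shown here, only the ring change has a measured counterpart, the step from compound 1 to compound 2, which stayed within the scatter; the chain extension has no counterpart among the measured compounds. With the amide tail so far tolerant of pyrrolidinyl, piperidinyl and methoxyphenylamino variants without any step beyond the scatter, no step beyond the scatter is expected in this assay either, so compound 4 is estimated at 30000 nM, range 12000 nM to 80000 nM. The expected step is a 1.2-fold lower number from compound 2 to compound 4 (0.09 log units; within the scatter), with the chain extension the main source of uncertainty.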

Compound 4, half-maximal inhibitory concentration: 7500 nM
Estimate against measurement, compound 4: 4.0-fold (0.60 log units) above; the measured number lies below the stated range.
By their numbers in this assay, from the lowest: compound 4; then compounds 3, 1 and 2 (each within the scatter of the next).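

In this assay, keeping the pyrrolidin-1-yl amide and changing only the chain gives a step beyond the scatter (a 4.3-fold lower number from compound 1 to compound 4 (0.64 log units; beyond the scatter)), whereas the amide changes among compound 1, compound 2 and compound 3 all stayed within it. Among these compounds, the two steps that change the amide and the chain together are also beyond the scatter (a 4.9-fold lower number from compound 2 to compound 4 (0.69 log units; beyond the scatter); a 3.2-fold lower number from compound 3 to compound 4 (0.51 log units; beyond the scatter)), which makes compound 4 the strongest of the four and places the only clear change at the chain rather than the amide ring. The data shown offer no explanation for this step.

Still open, going by these compounds, is whether the piperidin-1-yl and (3-methoxyphenyl)amino amides on the chain of compound 4 would give numbers within the scatter of compound 4, which would show whether the amide remains as tolerant there as on the shorter chain. Also open, on these data alone, is whether a still longer chain lowers the number further, and whether a carboxylic acid in place of the amide keeps the step.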